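This account rests on a few compounds, and the source may have more. Where it says the series, first, only, none or still open, it means among the compounds named here.

- compound 1 `COc1ccc(C(=O)c2ccc(OC)c3c2OC(C)(C)C=C3)c(NC(=O)CO)c1` gives 80 nM
- compound 2 `COc1ccc(C(=O)c2ccc(OC)c3c2C=CC(C)(C)O3)c(NC(=O)CN)c1` gives 420 nM

In a functional assay on A549 cells (Homo sapiens) for antiproliferative activity, read by MTT assay, with a stated time of 48 h (on this read-out higher numbers stand for weaker inhibition and lower numbers for stronger inhibition), compound 1 gives 80 nM as its result, the lower of the two numbers and so the stronger inhibition. Compound 2 gives 420 nM as its result, a gap beyond the usual scatter. These two compounds differ in more than one place, so they offer no clean single-change comparison.

The next compound, compound 3 `COc1ccc(C(=O)c2ccc(OC)c3c2OC(C)(C)C=C3)c(NC(=O)CN(C)C)c1`, keeps the core of compound 1 and changes one group: dimethylamino in place of hydroxy on a saturated chain carbon bound to a carbonyl carbon. Among the measured compounds shown here, no measured pair shows this change, so any forecast is uncertain. For the measured compounds named here, the only guide is that compound 1, at 80 nM in this assay, holds the lowest number so far, which leaves more room for a rise than for a fall. A modest move toward weaker inhibition is therefore expected, only a little beyond the scatter. The expected size of the change is a 2.5-fold higher number from compound 1 to compound 3 (0.40 log units; beyond the scatter) as estimated here. For compound 3 the estimated value is 200 nM, with an expected range from 60 nM to 700 nM for repeat measurements.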

Compound 3, half-maximal inhibitory concentration: 890 nM
The estimate for compound 3 lay 4.5-fold (0.65 log units) below the measured number; the measured number lies above the stated range.
By their numbers in this assay, from the lowest: compound 1; then compound 2; then compound 3.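

In this assay, putting dimethylamino in place of hydroxy on a saturated chain carbon bound to a carbonyl carbon gives an 11-fold higher number from compound 1 to compound 3 (1.05 log units; beyond the scatter), a large step toward weaker inhibition. Among the compounds shown here, this is the first clean reading of a single change in this set, and it shows that the number responds strongly to the group at this place on the core of compound 1; compound 2 differs from both other compounds in more than one place, so its steps to them cannot be read. The change alters several things at once, as the hydroxy has 1 heavy atom and 1 hydrogen-bond donor while the dimethylamino has 3 heavy atoms and 0 hydrogen-bond donors, and nothing measured here tells which of these matters.

Going by these compounds, with one step, it stays open whether the rise follows from losing the hydroxy or from gaining the dimethylamino. A methoxy or a methylamino group at the same place on the same core would help to separate those two readings, and a longer chain carrying the hydroxy would test how much room the position allows.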